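Removing the tert-butyl from the aroyl acrylic acid series

The source may hold more compounds than are shown below. What is called first, only, known or untested is meant among the compounds shown, and "the series" means these compounds.

Of the compounds shown here, three of the shared core have been measured in a functional assay on HeLa cells (Homo sapiens) for inhibition, read by MTT assay, with a stated time of 72 h; a lower number here means a stronger inhibitor, a higher number a weaker inhibitor. Compound 1 `O=C(O)/C=C/C(=O)c1ccc(Cl)cc1Cl` gives 62900 nM in this assay. Compound 2 `CC(C)(C)c1ccc(C(=O)/C=C/C(=O)O)cc1` gives 5100 nM, and compound 3 `Cc1ccc(C(=O)/C=C/C(=O)O)cc1C` gives 7280 nM. Compound 2 stands at the low end of these numbers: compound 3 sits within the scatter of it, so nothing separates the two, whereas the gap to compound 1 lies beyond the scatter.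

The next compound, compound 4 `O=C(O)/C=C/C(=O)c1ccccc1`, is compound 2 with the substituent taken off: hydrogen in place of tert-butyl on an aromatic carbon. Going by the values given here, no pair measured so far differs in one place only, so no measured step shows what this change does on its own. The values in hand only indicate that the bare core with the tert-butyl or the dimethyl pattern sits far from the dichloro pattern of compound 1, and nothing tells where an unsubstituted ring falls between them.

The expectation is a modest loss: the step from compound 2 to compound 4 is estimated at a 2.9-fold higher number from compound 2 to compound 4 (0.47 log units; beyond the scatter), a move to a higher number beyond the scatter, though with little to anchor it. Compound 4 is accordingly estimated at 15000 nM in this assay, within a range of 5000 nM to 45000 nM.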

Compound 4, half-maximal inhibitory concentration: 30600 nM
Compound 4: the middle estimate sits 2.0-fold (0.31 log units) below what was measured, within the range that was stated.
By their numbers in this assay, from the lowest: compounds 2 and 3 (each within the scatter of the next); then compound 4; then compound 1.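

In this assay the exchange of tert-butyl for hydrogen on an aromatic carbon of the six-membered ring, para to a group of 7 heavy atoms, is a 6.0-fold higher number from compound 2 to compound 4 (0.78 log units; beyond the scatter) and gives the series its first measured step that differs in one place only. This position is therefore not silent: with everything else held the same, the tert-butyl of compound 2 goes with the stronger inhibition, and the bare ring of compound 4 gives it up by a margin that lies beyond the usual scatter of this kind of measurement. Going by these compounds alone, nothing measured so far explains why this step has the size it has.

On these data alone, with only tert-butyl and hydrogen compared directly at this position, it stays open whether a shorter branched chain such as isopropyl, a linear chain such as n-butyl, or a methoxy or amine group would hold the number of compound 2 or fall back towards that of compound 4. Also open, as far as these compounds go, is whether the same exchange carries a step of similar size in a cell line other than the one used here.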